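The source may hold more compounds than are shown below. What is called first, only, known or untested is meant among the compounds shown, and "the series" means these compounds.

Of the compounds shown here, three sharing one core have been tested for toxicity toward a human blood-cell line, in an ADME assay on THP-1 cells (Homo sapiens) for cytotoxicity, read by MTT assay, with a stated time of 72 h; on this read-out lower numbers stand for an effect already at smaller amounts and higher numbers for an effect only at larger amounts of compound. Compound 1 `O=c1nc(-c2ccccc2)c2cc(-c3cccnc3)ccc2[nH]1` carries a pyridin-3-yl group on the core; in this assay compound 1 reaches only the assay limit of > 50000 nM. Compound 2 `Cc1cncc(-c2ccc3[nH]c(=O)nc(-c4ccccc4)c3c2)c1` adds a methyl to that pyridine, and compound 2 likewise stops at the limit of > 50000 nM. Compound 3 `O=c1nc(-c2ccccc2)c2cc(-c3ccc(F)cc3)ccc2[nH]1` bears a 4-fluorophenyl instead, and compound 3 too gives only the limit of > 50000 nM. The steps from compound 1 to compound 2 a step that the two limits leave unreadable from compound 1 to compound 2, from compound 1 to compound 3 a step that the two limits leave unreadable from compound 1 to compound 3 and from compound 2 to compound 3 a step that the two limits leave unreadable from compound 2 to compound 3 therefore cannot be sized, because of the limit of > 50000 nM in this assay, at which 3 of the 3 values shown sit.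

Compound 4 `N#Cc1ccc(-c2ccc3[nH]c(=O)nc(-c4ccccc4)c3c2)cc1` differs from compound 3 by cyano in place of fluoro on an aromatic carbon. No measured step sizes this change; the three shared limits suggest no toxicity appearing within the tested range. Compound 4 is therefore expected to sit at 50000 nM, between 20000 nM and 200000 nM, with the step from compound 3 to compound 4 estimated as a number no higher from compound 3 to compound 4 (the limit leaves the size open).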

Compound 4, half-maximal effective concentration: > 50000 nM
Compound 4 was reported as a limit; the forecaster's own chance of this, stated with the estimate: 85%; the middle value lies on the limit itself.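

Compound 4, like compound 1, compound 2 and compound 3, gives only a limit, so none of the steps linking compound 4 to the other three can be read: the limit of > 50000 nM in this assay, at which 4 of the 4 values shown sit. In this assay the compounds shown leave open how far apart these four truly lie.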